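A few compounds are considered here, and "the series" means these few. Any claim that something is new, unique, unknown or untested is made for them only; others in the source may bear on it.

The series shares the core of compound 1 `NNC(=O)CSc1nnc(-c2ccncc2)o1`, which in a functional assay on MCF7 cells (Homo sapiens) for cytotoxicity, read by MTT assay, with a stated time of 48 h (a lower number here means a stronger inhibitor, a higher number a weaker inhibitor), gives 3260 nM. Compound 2 `O=C(CSc1nnc(-c2ccncc2)o1)N/N=C/c1cccc(C(F)(F)F)c1` carries a trifluoromethyl-bearing aryl hydrazone, and in this assay compound 2 gives 14600 nM. Compound 3 `COc1cccc(/C=N/NC(=O)CSc2nnc(-c3ccncc3)o2)c1` differs from it by methoxy in place of trifluoromethyl on an aromatic carbon; in this assay compound 3 gives 13800 nM. Compound 3 stands second highest of the three numbers: its nearest neighbour is compound 2, where a 1.1-fold lower number from compound 2 to compound 3 (0.02 log units; within the scatter), and its furthest is compound 1, whose number is lower by a margin beyond the scatter.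

Compound 4 `O=C(CSc1nnc(-c2ccncc2)o1)N/N=C/c1ccc(Cl)cc1Cl` is not yet measured. Compared with compound 3 the change is 2,4-dichlorophenyl in place of 3-methoxyphenyl on a carbon with a double bond to nitrogen. Going by the values given here, the only measured step on the aryl hydrazone ring is a 1.1-fold lower number from compound 2 to compound 3 (0.02 log units; within the scatter); it swaps one ring substituent for another and left the number essentially unchanged. Among the compounds with values here, no measured step exchanges a methoxy for a dichloro pattern. Both aryl hydrazones sit well above compound 1. The expectation for compound 4 in this assay is therefore a step within the scatter, a 1.2-fold lower number from compound 3 to compound 4 (0.06 log units; within the scatter). For compound 4 the estimate in this assay is 12000 nM, with a range of 4000 nM to 36000 nM.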

Compound 4, half-maximal inhibitory concentration: 27900 nM
For compound 4 the middle estimate is 2.3-fold (0.37 log units) below the measured one; measured number inside the range.
By their numbers in this assay, from the lowest: compound 1; then compounds 3, 2 and 4 (each within the scatter of the next, the first and the last beyond it).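

In this assay, the aryl group on a carbon with a double bond to nitrogen is not a silent position: 2,4-dichlorophenyl in place of 3-methoxyphenyl gives a 2.0-fold higher number from compound 3 to compound 4 (0.31 log units; beyond the scatter) as a modest move, while the earlier ring swap, a 1.1-fold lower number from compound 2 to compound 3 (0.02 log units; within the scatter), left the number essentially unchanged. Both groups hold 8 heavy atoms and one six-membered aromatic ring of carbon only, but the hydrogen-bond acceptor of 3-methoxyphenyl is absent from 2,4-dichlorophenyl, and a single step cannot separate these differences from the chlorine pattern itself. No measurement on hand explains the step.

Open, going by these compounds, is whether the step follows the presence of chlorine or the 2,4-dichloro pattern. Also open, on these data alone, is how a phenyl ring carrying one chlorine, an amine or a carboxylic acid would read at this position.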